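Acetyl on the ring nitrogen: tolerability outlook

A few compounds are considered here, and "the series" means these few. Any claim that something is new, unique, unknown or untested is made for them only; others in the source may bear on it.

Two members of the series have been run in an ADME assay on HEK-293T cells (Homo sapiens) for cytotoxicity, with a stated time of 48 h; a lower number here means that less compound is tolerated, a higher number that more compound is tolerated. Compound 1 `CCc1ncnc(NC(CC)c2ccc(-c3ccccc3)cc2)c1Cl` gives > 10000 nM there, which is a limit of the assay rather than a number. Compound 2 `CCc1ncnc(NC(C)c2ccc3c(c2)NCCO3)c1Cl` likewise gives > 10000 nM in this assay, again only a limit. Both values therefore rest at the limit of > 10000 nM in this assay, at which 2 of the 2 values shown sit, so compound 2 stands at the edge of what the assay reports, with no number separating it from compound 1.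

Compound 3 `CCc1ncnc(NC(C)c2ccc3c(c2)N(C(C)=O)CCO3)c1Cl` is not yet measured. It differs from compound 2 by acetyl in place of hydrogen on a nitrogen on an aromatic ring in a ring. For the measured compounds named here, no measured step bears on this change. Compound 2 already sits at the limit, as noted. On that basis the step that the limit leaves unreadable from compound 2 to compound 3 is expected to be nothing beyond the scatter. Compound 3 is accordingly estimated at 15000 nM, within 5000 nM to 40000 nM, and most likely reported again only as a limit.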

Compound 3, half-maximal cytotoxic concentration: > 10000 nM
Compound 3 ended at the assay's limit (the forecaster's own chance of this, stated with the estimate: 75%); the middle value does not contradict the limit.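

Compound 2 and compound 3 both end as limits rather than numbers, so the swap of hydrogen for acetyl gives no readable step in this assay and the series stays flat at the ceiling: the limit of > 10000 nM in this assay, at which 3 of the 3 values shown sit.

The compounds shown leave open at what concentration any of them becomes cytotoxic in this assay and whether acetyl on the ring nitrogen changes that concentration at all.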